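The source may hold more compounds than are shown below. What is called first, only, known or untested is meant among the compounds shown, and "the series" means these compounds.

Of the compounds shown here, three built on one shared core have been tested in a functional assay on HEp-2 cells (Homo sapiens) for cytotoxicity, read by sulforhodamine B assay, with a stated time of 48 h; a higher number here means a weaker inhibitor, a lower number a stronger inhibitor. Compound 1 `O=CCN1N=C(c2ccc3ccccc3c2)CC1c1cccc([N+](=O)[O-])c1` gives 3870 nM, compound 2 `O=CCN1N=C(c2ccc3ccccc3c2)CC1c1ccccc1[N+](=O)[O-]` gives 3630 nM, and compound 3 `O=CCN1N=C(c2ccc3ccccc3c2)CC1c1cccc(Br)c1` gives 8780 nM, the highest of the three numbers, so compound 3 is the weakest inhibitor among them. The step of a 1.1-fold lower number from compound 1 to compound 2 (0.03 log units; within the scatter) stays within the scatter, while the steps of a 2.3-fold higher number from compound 1 to compound 3 (0.36 log units; beyond the scatter) and a 2.4-fold higher number from compound 2 to compound 3 (0.38 log units; beyond the scatter) are modest. Compound 4 `COc1ccc(C2CC(c3ccc4ccccc4c3)=NN2CC=O)cc1` has not yet been measured; it differs from compound 3 by 4-methoxyphenyl in place of 3-bromophenyl on a saturated ring carbon. Within the data shown here, no measured step swaps bromo for methoxy, so only the two modest steps ending at compound 3 hint at the size to expect. A modest step downward is expected, a 1.5-fold lower number from compound 3 to compound 4 (0.17 log units; within the scatter). Compound 4 is therefore estimated at 6000 nM, with a range from 2500 nM to 15000 nM.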

Compound 4, half-maximal inhibitory concentration: 3230 nM
The estimate for compound 4 lay 1.9-fold (0.27 log units) above the measured number; the range from low to high includes it.
By their numbers in this assay, from the lowest: compounds 4, 2 and 1 (each within the scatter of the next); then compound 3.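

At this saturated ring carbon, 4-methoxyphenyl gives a 2.7-fold lower number from compound 3 to compound 4 (0.43 log units; beyond the scatter), so a phenyl ring without a nitro group can also reach the lower numbers. It stands level with both nitro compounds, with a 1.1-fold lower number from compound 2 to compound 4 (0.05 log units; within the scatter) and a 1.2-fold lower number from compound 1 to compound 4 (0.08 log units; within the scatter), leaving compound 3 alone at the higher number. No supporting evidence explains this difference. The change from 3-bromophenyl to 4-methoxyphenyl alters both the group and its place on the phenyl ring, and these two changes remain unseparated. As far as these compounds go, how a phenyl ring carrying an amine or a carboxylic acid would behave at this carbon also stays open.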